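The source may hold more compounds than are shown below. What is called first, only, known or untested is meant among the compounds shown, and "the series" means these compounds.

Measured in an ADME assay on L6 cells (Rattus norvegicus) for cytotoxicity; on this read-out lower numbers stand for stronger inhibition and higher numbers for weaker inhibition:
- Compound 1 `O=[N+]([O-])c1ncn(CCCNS(=O)(=O)c2ccc(C(F)(F)F)cc2)n1`: 235000 nM
- Compound 2 `Cc1ccc(S(=O)(=O)NCCCn2cnc([N+](=O)[O-])n2)cc1`: > 307000 nM (a limit, not a number)
- Compound 3 `O=[N+]([O-])c1ncn(CCCNS(=O)(=O)Cc2ccccc2)n1`: > 307000 nM (a limit, not a number)

Compound 2 gives no number, only (the limit of > 307000 nM in this assay, at which 2 of the 3 values shown sit). Its true position is therefore unknown, and any step starting from it can only be judged roughly.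

The next compound to be measured is compound 4 `O=[N+]([O-])c1ncn(CCCNS(=O)(=O)c2ccc(-c3ccccc3)cc2)n1`. It carries phenyl in place of methyl on an aromatic carbon, para to a large group: phenyl in place of methyl on an aromatic carbon.

Two measured steps lie nearby. Exchanging trifluoromethyl for methyl on an aromatic carbon gave an at least 1.3-fold higher number from compound 1 to compound 2 (0.11 log units; that floor lies within the scatter), so it shows no change beyond the scatter. Exchanging 4-methylphenyl for benzyl on a sulfonyl sulfur gave a step that the two limits leave unreadable from compound 2 to compound 3, so it tells us little. Neither step involves phenyl, which makes any forecast loose.

Among the compounds with values here, the best anchor is compound 1, the only compound with a true number, at 235000 nM. It suggests that a group other than methyl at this place can bring a reading within the measurable range, so a moderately lower number is expected, though another limit remains possible. The expected change is an at least 2.3-fold lower number from compound 2 to compound 4 (0.37 log units; beyond the scatter). Compound 4 is estimated at 130000 nM, with an expected range from 45000 nM to 307000 nM.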

Compound 4, half-maximal inhibitory concentration: 50000 nM
Compound 4: middle estimate off by 2.6-fold (0.41 log units), on the high side, within the range that was stated.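

Placing phenyl on this aromatic carbon produces the first change in this assay that lies clearly beyond the scatter: replacing methyl gives an at least 6.1-fold lower number from compound 2 to compound 4 (0.78 log units; beyond the scatter), and replacing trifluoromethyl gives a 4.7-fold lower number from compound 1 to compound 4 (0.67 log units; beyond the scatter). Within the data shown here, the earlier exchange at this place, between trifluoromethyl and methyl, showed no change beyond the scatter, so the new result is the first sign that the reading responds to what sits here. The step from methyl can be read only as a minimum, because compound 2 gives a limit and not a number: the limit of > 307000 nM in this assay, at which 2 of the 4 values shown sit.

A single phenyl compound cannot show whether the lower number comes from the aromatic ring itself or simply from a larger group at this place. Comparing phenyl with cyclohexyl, which has the same number of ring carbons but is not aromatic, or with pyridyl, which has a nitrogen in the ring, would help separate these two readings.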